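Replacing a Fluoropyridine by a Methylsulfonylphenyl Ring

This account rests on a few compounds, and the source may have more. Where it says the series, first, only, none or still open, it means among the compounds named here.

Measured compounds:
Compound 1, `CC(C)OC(=O)N1CCC(Oc2ncnc3c2CCN3c2ccc(-c3nccs3)cc2F)CC1`, gives 79.4 nM.
Compound 2, `COCCOC(=O)N1CCC(Oc2ncnc3c2CCN3c2ccc(S(C)(=O)=O)cc2F)CC1`, gives 316 nM.
Compound 3, `CC(C)OC(=O)N1CCC(Oc2ncnc3c2CCN3c2ccc(F)cn2)CC1`, gives > 10000 nM.

All three were tested in a functional assay on CHO-K1 cells for agonist activity at Glucose-dependent insulinotropic receptor (Homo sapiens), read by a luciferase reporter, with a stated time of 5 h; on this read-out higher numbers stand for an effect only at larger amounts of compound and lower numbers for an effect already at smaller amounts. Compound 1 and compound 2 both return numbers. For compound 3 the result is a limit of the assay and not a number; compound 3 stands at the limit of > 10000 nM in this assay, at which 1 of the 3 values shown sits. It is therefore the only one of the three whose position on the scale cannot be placed.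

Compound 4, `Cc1cc(S(C)(=O)=O)ccc1N1CCc2c(OC3CCN(C(=O)OC(C)C)CC3)ncnc21`, has not yet been measured. It differs from compound 3 in one place: 2-methyl-4-(methylsulfonyl)phenyl in place of 5-fluoropyridin-2-yl on a nitrogen on an aromatic ring in a ring. The aryl ring on that nitrogen in compound 4 carries the same methylsulfonyl substituent as the ring in compound 2, which gives 316 nM, while compound 4 keeps the isopropyl carbamate of compound 1, which gives 79.4 nM.

No step between measured compounds is shown, so the size of the change from compound 3 can only be expected from the compounds that do give numbers. Compound 4 is expected to come in at about 150 nM, with a range from 40 nM to 800 nM. This estimate implies an expected step of an at least 66-fold lower number from compound 3 to compound 4 (1.82 log units; beyond the scatter), well beyond the scatter and toward effect at smaller amounts.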

Compound 4, half-maximal effective concentration: 100 nM
Beside the measured number, compound 4's estimate is 1.5-fold (0.18 log units) above it; measured number inside the range.
By their numbers in this assay, from the lowest: compounds 1 and 4 (each within the scatter of the next); then compound 2. At a limit, above all of these: compound 3.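

In this assay, putting 2-methyl-4-(methylsulfonyl)phenyl in place of 5-fluoropyridin-2-yl on the nitrogen, with the isopropyl carbamate and the rest of the molecule unchanged, gives an at least 100-fold lower number from compound 3 to compound 4 (2.00 log units; beyond the scatter). Among the compounds shown here, this is the first step that can be read in one place alone, and it shows that the aryl group on this nitrogen can by itself move a compound from a limit of the assay to a measured number. Compound 3 gives a limit and not a number, so the size of the step is only a minimum: the limit of > 10000 nM in this assay, at which 1 of the 4 values shown sits.

The change swaps the ring nitrogen and fluorine for a methyl and a methylsulfonyl group all at once, so these compounds do not tell which of these parts accounts for the step. From the compounds shown here alone, it also remains open whether a pyridine ring carrying the methylsulfonyl group, a phenyl ring without the methyl group, or a nitrile in place of the methylsulfonyl group would give a number in this assay.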